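Retinoid imidazole series: ester in place of hydroxyphenyl amide

The source may hold more compounds than are shown below. What is called first, only, known or untested is meant among the compounds shown, and "the series" means these compounds.

Measured compounds:
compound 1 `CC1=C(/C=C/C(C)=C/C=C/C(C)=C\C(=O)Nc2ccc(O)cc2)C(C)(C)CCC1n1ccnc1` — "not determined" (no result reported)
compound 2 `CC1=C(/C=C/C(C)=C/C=C/C(C)=C/C(=O)Nc2ccc(O)cc2)C(C)(C)CCC1n1ccnc1` — 24 nM

Among the compounds with values here, in a functional assay on T47D cells for inhibition of cytochrome P450 26A1 (Homo sapiens) (a lower number here means a stronger inhibitor, a higher number a weaker inhibitor), compound 2 gives 24 nM, the only number in the set; compound 1 has no result, and the pair differ in that (the fact that one of compounds 1 and 2 is drawn with a defined configuration and the other without, at the place where they differ). Compound 3 `COC(=O)/C=C(C)/C=C/C=C(C)/C=C/C1=C(C)C(n2ccnc2)CCC1(C)C` carries the change (methoxy in place of (4-hydroxyphenyl)amino on a carbonyl carbon). Within the data shown here, no measured step of this kind exists, so the expectation rests on compound 2 alone. The loss of the (4-hydroxyphenyl)amino group is expected to weaken inhibition somewhat, giving an estimated step of a 2.5-fold higher number from compound 2 to compound 3 (0.40 log units; beyond the scatter). Compound 3 is therefore estimated at 60 nM, within 15 nM to 300 nM.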

Compound 3, half-maximal inhibitory concentration: 215 nM
For compound 3 the middle estimate is 3.6-fold (0.55 log units) below the measured one; the measured number falls inside the stated range.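

In this assay, methoxy in place of (4-hydroxyphenyl)amino on a carbonyl carbon gives a 9.0-fold higher number from compound 2 to compound 3 (0.95 log units; beyond the scatter). The (4-hydroxyphenyl)amino group therefore counts at this position, yet it is not required for inhibition, as compound 3 still gives 215 nM. Nothing available bears on the cause of this step.

The compounds shown leave open which part of the (4-hydroxyphenyl)amino group accounts for the difference. Also open, as far as these compounds go, is how phenylamino or a carboxylic acid at the same carbonyl carbon would read.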